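A Fluoro Swap on Compound 3

The source may report more compounds than this note shows. Statements on the series, on what has been measured and on what is new or still open speak of the compounds shown alone.

- compound 1 `O=C1C2=C(CCCC2)C(=O)N1c1ccc(Cl)cc1F`: 240 nM
- compound 2 `O=C(O)c1cc(N2C(=O)C3=C(CCCC3)C2=O)c(F)cc1Cl`: 3160 nM
- compound 3 `COC(=O)c1cc(N2C(=O)C3=C(CCCC3)C2=O)ccc1Cl`: 1620 nM

In a functional assay on the whole organism with Scenedesmus acutus as the target, with a stated time of 20 h (a lower number here means a stronger inhibitor, a higher number a weaker inhibitor), compound 3 at 1620 nM lies within the scatter of compound 2, and its number is clearly higher than that of compound 1. The next compound, compound 4 `COC(=O)c1cc(N2C(=O)C3=C(CCCC3)C2=O)c(F)cc1Cl`, has not been measured. It differs from compound 3 by one change: fluoro in place of hydrogen on an aromatic carbon.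

Among the measured compounds shown here, no measured step shows this change directly. For the measured compounds named here, the one available step, a 13-fold higher number from compound 1 to compound 2 (1.12 log units; beyond the scatter), is large, but it concerns carboxy in place of hydrogen, so it offers no direct guide. Indirect evidence comes from compound 1, which carries the fluoro group and reads 240 nM, although it also lacks the methoxycarbonyl group. Compound 2 also carries fluoro, yet reads 3160 nM. A moderate move towards a lower number therefore seems likely, though it may not clear the scatter. The estimated change is a 2.5-fold lower number from compound 3 to compound 4 (0.40 log units; beyond the scatter). Compound 4 is expected at about 650 nM, with an estimated range of 150 nM to 2200 nM.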

Compound 4, half-maximal inhibitory concentration: 170 nM
Beside the measured number, compound 4's estimate is 3.8-fold (0.58 log units) above it; low and high end bracket the measured number.
By their numbers in this assay, from the lowest: compounds 4 and 1 (each within the scatter of the next); then compounds 3 and 2 (each within the scatter of the next).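

In this assay, among the compounds shown here, fluoro in place of hydrogen, on the aromatic carbon ortho to a large group, meta to a chloro group and para to a methoxycarbonyl group, gives a 9.5-fold lower number from compound 3 to compound 4 (0.98 log units; beyond the scatter) as the first direct reading of this change at this position. With fluoro present, adding the methoxycarbonyl group gives a 1.4-fold lower number from compound 1 to compound 4 (0.15 log units; within the scatter) so those two compounds read alike, while methyl in place of hydrogen on an oxygen next to a carbonyl group gives a 19-fold lower number from compound 2 to compound 4 (1.27 log units; beyond the scatter) and so separates the methyl ester from the free carboxy compound. No measurement shown here gives a reason for any of these steps.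

As far as these compounds go, whether chloro, methoxy or an amine on this same carbon would read like fluoro remains open. So does how a longer ester chain in place of the methoxycarbonyl group would read alongside fluoro.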